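A few compounds are considered here, and "the series" means these few. Any claim that something is new, unique, unknown or untested is made for them only; others in the source may bear on it.

Compound 1 `O=C(NCc1ccc(S(=O)(=O)c2cccc(C(F)(F)F)c2)cc1)c1cc2cnccc2[nH]1` - 3 nM
Compound 2 `O=C(NCc1ccc(S(=O)(=O)c2ccccc2)cc1)c1cc2cnccc2[nH]1` - 18 nM

Among the measured compounds shown here, in a functional assay on A2780 cells (Homo sapiens) for inhibition, read by sulforhodamine B assay, with a stated time of 72 h (on this read-out lower numbers stand for stronger inhibition and higher numbers for weaker inhibition), compound 2 gives 18 nM, the higher of the two numbers so far. Compound 3 `Cc1cccc(S(=O)(=O)c2ccc(CNC(=O)c3cc4cnccc4[nH]3)cc2)c1` differs from it by methyl in place of hydrogen on an aromatic carbon, meta to a large group (methyl in place of hydrogen on an aromatic carbon). For the measured compounds named here, the only measured step bearing on this is a 6.0-fold higher number from compound 1 to compound 2 (0.78 log units; beyond the scatter), with hydrogen in place of trifluoromethyl. Read in reverse, it points to a lower number for compound 3, though no methyl compound has been measured. A smaller change is expected, an estimated 2.3-fold lower number from compound 2 to compound 3 (0.35 log units; beyond the scatter). Compound 3 is expected at about 8 nM, within an estimated range of 3 nM to 20 nM.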

Compound 3, half-maximal inhibitory concentration: 4 nM
Compound 3: middle estimate off by 2.0-fold (0.30 log units), on the high side; measured number inside the range.
By their numbers in this assay, from the lowest: compounds 1 and 3 (each within the scatter of the next); then compound 2.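

Methyl on this aromatic carbon, meta to a large group, also lowers the number, with a 4.5-fold lower number from compound 2 to compound 3 (0.65 log units; beyond the scatter) in this assay, so the earlier gain is not confined to trifluoromethyl. The direct change between these two groups is a 1.3-fold higher number from compound 1 to compound 3 (0.12 log units; within the scatter), so this assay does not separate them. From the compounds shown here alone, whether a chlorine atom, a methoxy group or an amine would act in the same way at this position remains open, as does the effect of methyl on the other carbons of this ring. No measurement shown here explains these steps.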